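Replacing 4-nitrophenyl with thiophen-2-yl on compound 3

A few compounds are considered here, and "the series" means these few. Any claim that something is new, unique, unknown or untested is made for them only; others in the source may bear on it.

Three related compounds share one core and differ at a single aromatic carbon: compound 1 `O=C(NNc1ccnc2cc(Cl)ccc12)c1ccccc1/N=C/c1ccc(Cl)cc1`, compound 2 `Cc1ccc(/C=N/c2ccccc2C(=O)NNc2ccnc3cc(Cl)ccc23)cc1` and compound 3 `O=C(NNc1ccnc2cc(Cl)ccc12)c1ccccc1/N=C/c1ccc([N+](=O)[O-])cc1`. In a physicochemical assay for lipophilicity, measured as octanol-water partition (on this read-out higher numbers stand for higher lipophilicity and lower numbers for lower lipophilicity), compound 1 gives 5.62. Compound 2 gives 5.31. Compound 3 gives 4.58, the lowest of the three numbers.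

The next structure, compound 4 `O=C(NNc1ccnc2cc(Cl)ccc12)c1ccccc1/N=C/c1cccs1`, carries thiophen-2-yl in place of 4-nitrophenyl on a carbon with a double bond to nitrogen. Within the data shown here, no measured step exchanges a whole ring, so the evidence is indirect. Methyl in place of chloro gave a number 0.31 log units lower from compound 1 to compound 2 (beyond the scatter). Among the measured compounds shown here, two steps bear more closely on the change, since they put nitro in place of another group: nitro in place of chloro gave a number 1.04 log units lower from compound 1 to compound 3 (beyond the scatter), and nitro in place of methyl gave a number 0.73 log units lower from compound 2 to compound 3 (beyond the scatter). Here the nitro group leaves, so a modest rise in this assay is expected, smaller than the drop seen in reaching compound 3 from compound 1 a number 1.04 log units lower from compound 1 to compound 3 (beyond the scatter). The expected change is a number 0.32 log units higher from compound 3 to compound 4 (beyond the scatter). With so little direct evidence, the range is wide. For compound 4 the estimated value is 4.9, with an expected range from 4.4 to 5.4.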

Compound 4, partition coefficient: 4.78
Compound 4: middle estimate off by 0.12 log units, on the high side, and the stated range covers the measured number.
By their numbers in this assay, from the lowest: compounds 3 and 4 (each within the scatter of the next); then compound 2; then compound 1.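

Among these compounds, compound 4 is the first case here in which a whole ring changes on the carbon with a double bond to nitrogen, where the earlier compounds changed only one group on a six-membered ring. Even so, in this assay the exchange of 4-nitrophenyl for the five-membered thiophen-2-yl leaves the two compounds within the scatter of each other (a number 0.20 log units higher from compound 3 to compound 4 (within the scatter)), so this position accepts a change of ring with no clear shift in the read-out when 4-nitrophenyl is the starting point. The same thiophen-2-yl does stand clearly apart from both 4-methylphenyl (a number 0.53 log units lower from compound 2 to compound 4 (beyond the scatter)) and 4-chlorophenyl (a number 0.84 log units lower from compound 1 to compound 4 (beyond the scatter)), which shows that the size of the step depends on which group leaves as well as on the one that enters.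

Still open, from the compounds shown here alone, is where plain phenyl, furan-2-yl, a thiophene ring bearing an amine or a carboxylic acid, or a longer chain such as butyl would fall at this carbon. Nothing measured alongside these numbers explains why compound 4 falls where it does.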